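The source may report more compounds than this note shows. Statements on the series, on what has been measured and on what is new or still open speak of the compounds shown alone.

Measured compounds in an ADME assay on Vero cells (Chlorocebus sabaeus) for cytotoxicity, read by MTT assay, with a stated time of 72 h; a lower number here means that less compound is needed, a higher number that more compound is needed for the effect:
compound 1 `Cc1ccccc1C(=O)Nc1nc(-c2ccccn2)cs1` gives 6300 nM
compound 2 `O=C(Nc1nc(-c2ccccn2)cs1)c1ccc(OCc2ccccc2)cc1` gives 2300 nM
compound 3 `COc1ccc(C(=O)Nc2nc(-c3ccccn3)cs2)cc1` gives 9200 nM

Compound 1 sits close to compound 3, the two values lying within the usual scatter of each other, while compound 2 gives a clearly lower number than either. Going by the values given here, the only step between measured compounds that differ in a single place is a 4.0-fold higher number from compound 2 to compound 3 (0.60 log units; beyond the scatter); it concerns the group on the oxygen on the aromatic ring and leaves the rest of the shared core untouched.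

Compound 4 `O=C(Nc1nc(-c2ccccn2)cs1)c1ccccc1Br` differs from compound 1 in one place: bromo in place of methyl on an aromatic carbon. Among the compounds with values here, no measured pair shows bromo in place of methyl on an aromatic carbon, and no measured pair varies that carbon at all, so the data hold nothing that speaks to the size or direction of this step. The step from compound 2 to compound 3 lies elsewhere in the molecule and cannot be carried over. Compound 4 is therefore expected to give a number much like that of compound 1. The expected step is no change at the digits printed from compound 1 to compound 4 (within the scatter), meaning no change beyond the scatter. The estimate for compound 4 is 6300 nM, with a range from 2800 nM to 14000 nM, the width reflecting the absence of any bearing step.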

Compound 4, half-maximal effective concentration: 3500 nM
The estimate for compound 4 lay 1.8-fold (0.26 log units) above the measured number; the measured number falls inside the stated range.
By their numbers in this assay, from the lowest: compounds 2, 4, 1 and 3 (each within the scatter of the next, the first and the last beyond it).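

In this assay, going by these compounds alone, the exchange of methyl for bromo on an aromatic carbon ortho to a large group gives a 1.8-fold lower number from compound 1 to compound 4 (0.26 log units; within the scatter), and this is the first reading at this position, since the earlier comparison concerned only the group on the oxygen on the aromatic ring. For this single pair, then, the 2-methylphenyl and 2-bromophenyl forms of the shared core cannot be told apart in this cytotoxicity read-out, so the change from a methyl to a bromo at this carbon has no effect that can be resolved from the usual scatter. Nothing available offers a reason for this outcome, and the result rests on the numbers alone.

Going by these compounds, one pair at one carbon says nothing about how far this tolerance extends, and it remains open whether an amine, a carboxylic acid or a longer chain such as propyl at the same carbon would shift the number beyond the scatter. On these data alone, it is also open whether a bromo placed elsewhere on this ring, or on the ring of compound 2 or compound 3, would behave as it does in compound 4.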